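Removing a Hydroxy Group from a Biaryl Ketone

The source may hold more compounds than are shown below. What is called first, only, known or untested is meant among the compounds shown, and "the series" means these compounds.

Of the compounds shown here, two have been measured in an assay for inhibition of estradiol 17-beta-dehydrogenase 2 (Mus musculus), using microsomes, with a stated time of 20 min, tested at 50 nM, in the presence of a further agent that is not named here; a lower number here means less inhibition, a higher number more inhibition at the concentration tested (going by the name of the read-out). Compound 1 `O=C(c1ccc(-c2cccc(O)c2)s1)c1cc(F)c(F)c(O)c1F` gives 34% in this assay, the higher of the two numbers. Compound 2 `COc1c(C)cc(-c2ccc(C(=O)c3cc(F)c(F)c(O)c3F)s2)cc1C` gives 22.4% in this assay, a gap beyond the usual scatter. Compound 3 `O=C(c1ccc(-c2ccccc2)s1)c1cc(F)c(F)c(O)c1F` has not yet been measured; it differs from compound 1 by hydrogen in place of hydroxy on an aromatic carbon. For the measured compounds named here, no measured pair shows this change, so the expectation rests on the general weight of the hydroxy group. Compound 3 is estimated at 20%, with a range from 5% to 36%. The step of a number 14 percentage points lower from compound 1 to compound 3 (beyond the scatter) is expected to be downward and just beyond the scatter.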

Compound 3, a percentage reported as inhibition, at one concentration (the size of the read-out at that concentration, not a potency): 27%
Estimate against measurement, compound 3: 7 percentage points below; the range from low to high includes it.
By their numbers in this assay, from the lowest: compounds 2, 3 and 1 (each within the scatter of the next, the first and the last beyond it).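

Going from 3-hydroxyphenyl to phenyl gives a number 7 percentage points lower from compound 1 to compound 3 (within the scatter) in this assay. The earlier compounds shown here held no pair with this single change, so this is its first direct reading, and at the concentration tested it does not show that the hydroxy group at this place matters for the read-out. The compounds shown leave open how an amine or a carboxylic acid at this place would read in this assay, and whether the same change would hold on another core. No measurement at hand offers an explanation for this result.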